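Adding a chloro group to compound 3

The source may report more compounds than this note shows. Statements on the series, on what has been measured and on what is new or still open speak of the compounds shown alone.

Compound 1 `O=C(CSC(=S)N[C@H]1CCOC1=O)Nc1cccc(C(F)(F)F)c1` gives 3130 nM
Compound 2 `CSC(=S)N[C@H]1CCOC1=O` gives > 128000 nM (a limit of the assay)
Compound 3 `O=C(CCl)Nc1ccc(C(=O)/C=C/c2ccccc2)cc1` gives 2480 nM

In a functional assay on MCF7 cells (Homo sapiens) for cytotoxicity, read by MTT assay, with a stated time of 72 h (on this read-out lower numbers stand for stronger inhibition and higher numbers for weaker inhibition), compound 3 gives 2480 nM and stands within the scatter of compound 1 at 3130 nM on the numbers shown. Compound 2 reports only a limit (> 128000 nM). Compound 4 `O=C(CCl)Nc1ccc(C(=O)/C=C/c2cccc(Cl)c2)cc1` differs from compound 3 by chloro in place of hydrogen on an aromatic carbon, meta to a large group (chloro in place of hydrogen on an aromatic carbon). For the measured compounds named here, no measured pair shows this change, so no shift beyond the scatter is expected in this assay. The expected 1.2-fold lower number from compound 3 to compound 4 (0.09 log units; within the scatter) is therefore small. Compound 4 is estimated at 2000 nM (expected range 750 nM to 5500 nM).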

Compound 4, half-maximal inhibitory concentration: 5340 nM
Compound 4: the middle estimate sits 2.7-fold (0.43 log units) below what was measured, within the range that was stated.
By their numbers in this assay, from the lowest: compounds 3, 1 and 4 (each within the scatter of the next, the first and the last beyond it). At a limit, above all of these: compound 2.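

For the compounds shown here, the change from phenyl to 3-chlorophenyl gives a 2.2-fold higher number from compound 3 to compound 4 (0.33 log units; beyond the scatter) in this assay and is the first reading for this position. Here, chloro in place of hydrogen on this aromatic carbon raises the number rather than lowering it, although the step is modest. Nothing shown offers a cause for this shift. As far as these compounds go, what a fluoro group, a methoxy group or an amine would do on the same carbon stays open. So does the effect of chloro on the other carbons of that ring.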